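A Shorter Unsaturated Acid Arm on the Oxime Carbon

The compounds below may be only part of what the source reports. "The series", "measured", "known", "first", "only" and "open" are said of these compounds alone.

Of the compounds shown here, three sharing one core have been measured in a functional assay for inhibition of Polyunsaturated fatty acid 5-lipoxygenase (Homo sapiens); on this read-out lower numbers stand for stronger inhibition and higher numbers for weaker inhibition. Compound 1, `CC/C(=N\OC(c1ccc(OCc2ccc3ccccc3n2)cc1)C1CCCCC1)C(=O)O`, gives 30 nM. Compound 2, `O=C(O)/C(=N/OC(c1ccc(OCc2ccc3ccccc3n2)cc1)C1CCCCC1)c1ccccc1`, gives 31 nM. Compound 3, `C/C(CCCC(=O)O)=N\OC(c1ccc(OCc2ccc3ccccc3n2)cc1)C1CCCCC1`, gives 59 nM, the highest of the three numbers, though a 2.0-fold higher number from compound 1 to compound 3 (0.29 log units; within the scatter) and a 1.9-fold higher number from compound 2 to compound 3 (0.28 log units; within the scatter), so no order among them can be claimed.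

Compound 4, `CC(/C=C/C(=O)O)=N\OC(c1ccc(OCc2ccc3ccccc3n2)cc1)C1CCCCC1`, is not yet measured. It differs from compound 3 in one place: 2-carboxyethenyl in place of 3-carboxypropyl on a carbon with a double bond to nitrogen. Going by the values given here, none of the measured steps changes this part of the molecule in the same way, so the closest guidance comes from the steps that rework the acid-bearing group as a whole, a 2.0-fold higher number from compound 1 to compound 3 (0.29 log units; within the scatter) and a 1.9-fold higher number from compound 2 to compound 3 (0.28 log units; within the scatter), both modest in size and both within the scatter. On that basis the step from compound 3 to compound 4 is expected to stay small, a 1.2-fold lower number from compound 3 to compound 4 (0.07 log units; within the scatter), in no clear direction. Compound 4 is therefore estimated at 50 nM in this assay, with a range from 20 nM to 150 nM.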

Compound 4, half-maximal inhibitory concentration: 40 nM
Compound 4: middle estimate off by 1.3-fold (0.10 log units), on the high side; low and high end bracket the measured number.
By their numbers in this assay, from the lowest: compounds 1, 2, 4 and 3 (each within the scatter of the next).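

Exchanging 3-carboxypropyl for 2-carboxyethenyl on the carbon with a double bond to nitrogen gives a 1.5-fold lower number from compound 3 to compound 4 (0.17 log units; within the scatter) in this assay and so shows that this position accepts a chain with one heavy atom fewer and one more double bond without a step beyond the scatter. The acid-bearing group of compound 4 also stays close to the other two, with a 1.3-fold higher number from compound 2 to compound 4 (0.11 log units; within the scatter) and a 1.3-fold higher number from compound 1 to compound 4 (0.12 log units; within the scatter), so the four acid-bearing groups shown fall into no order. Nothing available explains these small steps.

Chain length and the double bond change together in this step, so 2-carboxyethyl, which would separate the two, remains an open case. From the compounds shown here alone, how this position responds to a methyl ester or an amine in place of the carboxylic acid also stays open.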